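The compounds below may be only part of what the source reports. "The series", "measured", "known", "first", "only" and "open" are said of these compounds alone.

In a functional assay on SW480 cells (Homo sapiens) for cytotoxicity, read by MTT assay, with a stated time of 48 h (a lower number here means a stronger inhibitor, a higher number a weaker inhibitor), compound 1 `Cc1cccc(Cn2cc(COc3ccc4c(=O)ccoc4c3)nn2)c1` gives 11700 nM. Compound 2 `O=c1ccoc2cc(OCc3cn(Cc4cccc([N+](=O)[O-])c4)nn3)ccc12` gives only a limit, > 100000 nM, so where exactly it stands is not known; this is the limit of > 100000 nM in this assay, at which 1 of the 2 values shown sits. Among the measured compounds shown here, the step of an at least 8.5-fold higher number from compound 1 to compound 2 (0.93 log units; beyond the scatter) is the one measured change. Compound 3 `N#Cc1cccc(Cn2cc(COc3ccc4c(=O)ccoc4c3)nn2)c1` differs from compound 2 by cyano in place of nitro on an aromatic carbon. For the measured compounds named here, no measured step covers cyano, so the bearing of the step from compound 1 to compound 2 is indirect. Compound 3 is expected to sit between the two measured points, with the estimated step of an at least 1.6-fold lower number from compound 2 to compound 3 (0.22 log units; that floor lies within the scatter), giving an expected value of 60000 nM in this assay, in the range 15000 nM to 200000 nM.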

Compound 3, half-maximal inhibitory concentration: > 100000 nM
Compound 3: no number, only a limit; the forecaster's own chance of this, stated with the estimate: 45%; middle value at least 1.6-fold (0.22 log units) away from the limit.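

In this assay, cyano replaces methyl on the same aromatic carbon with an at least 8.5-fold higher number from compound 1 to compound 3 (0.93 log units; beyond the scatter), so a second group, not nitro alone, ends up far from compound 1. The step between compound 2 and compound 3 cannot be read, and nitro and cyano cannot be ranked against each other, as both compounds give only a limit: the limit of > 100000 nM in this assay, at which 2 of the 3 values shown sit.

Among the compounds shown, only methyl at this position gives a real number. Going by these compounds, whether an amine, a methoxy group or a longer chain such as ethyl would also give one remains open.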